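Swapping the Naphthalene Substituent in Endothelin Receptor Sulfonamides

The source may report more compounds than this note shows. Statements on the series, on what has been measured and on what is new or still open speak of the compounds shown alone.

compound 1, `Cc1noc(NS(=O)(=O)c2cccc3c(Cl)cccc23)c1C`: 24000 nM
compound 2, `Cc1noc(NS(=O)(=O)c2cccc3c(C(C)(C)O)cccc23)c1C`: 2890 nM

In an assay on VSM-A10 cells for antagonist activity at Endothelin-1 receptor (Rattus norvegicus) (on this read-out lower numbers stand for stronger inhibition and higher numbers for weaker inhibition), compound 2 holds the lowest of the two numbers; compound 1 sits an 8.3-fold lower number from compound 1 to compound 2 (0.92 log units; beyond the scatter) away. Compound 3, `Cc1noc(NS(=O)(=O)c2cccc3c(N/C(S)=N/c4ccccc4)cccc23)c1C`, carries a group of 10 heavy atoms (7 carbon, 2 nitrogen, 1 sulfur; one six-membered aromatic ring of carbon only) in place of a group of 4 heavy atoms (3 carbon, 1 oxygen; no ring), on an aromatic carbon, ortho to a fused ring and meta to a fused ring. Going by the values given here, the only measured step, an 8.3-fold lower number from compound 1 to compound 2 (0.92 log units; beyond the scatter), concerns the same position but a different exchange, so it gives no direct guide for this larger group; the direction is open. Compound 3 is therefore estimated at 2000 nM, with a range from 300 nM to 15000 nM. This estimate means a step of a 1.4-fold lower number from compound 2 to compound 3 (0.16 log units; within the scatter).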

Compound 3, half-maximal inhibitory concentration: 150 nM
Compound 3: the middle estimate sits 13-fold (1.12 log units) above what was measured; the whole stated range lies above it.
By their numbers in this assay, from the lowest: compound 3; then compound 2; then compound 1.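

In this assay this position on the shared core does more than the two smaller groups could show: the large group with its six-membered aromatic ring gives a 19-fold lower number from compound 2 to compound 3 (1.28 log units; beyond the scatter) and, measured against chloro, a 160-fold lower number from compound 1 to compound 3 (2.20 log units; beyond the scatter). Size at this place is therefore no barrier to a low number, at least for this one group. Nothing available here explains the gain. Which part of the new group matters stays open. As far as these compounds go, whether a plain amine or a urea, with oxygen instead of sulfur, would keep the number this low is unknown.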